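A few compounds are considered here, and "the series" means these few. Any claim that something is new, unique, unknown or untested is made for them only; others in the source may bear on it.

Among the measured compounds shown here, compound 2 `COc1ccc(C2CC(c3ccccc3)=NN2C2=NC(=O)/C(=C3\C(=O)Nc4ccc(Br)cc43)S2)cc1` stands lowest of the two numbers measured so far in a functional assay on cells (Cancer cell lines, Homo sapiens) for cytotoxicity, read by sulforhodamine B assay, with a stated time of 48 h (a lower number here means a stronger inhibitor of growth, a higher number a weaker inhibitor of growth), where compound 2 gives 190 nM. For the measured compounds named here, its only neighbour is compound 1 `O=C1N=C(N2N=C(c3ccccc3)CC2c2ccccc2O)S/C1=C1/C(=O)Nc2ccc(Br)cc21`, which in this assay gives 210 nM; the step of a 1.1-fold lower number from compound 1 to compound 2 (0.04 log units; within the scatter) lies within the scatter, so the two cannot be ordered. Compound 3 `COc1ccc(C2=NN(C3=NC(=O)/C(=C4\C(=O)Nc5ccc(Br)cc54)S3)C(c3ccc(OC)cc3)C2)cc1` differs from compound 2 by methoxy in place of hydrogen on an aromatic carbon; cut one bond further out, the same difference reads phenyl to 4-methoxyphenyl. Going by the values given here, no measured step touches this position. Among the compounds with values here, the single step in hand concerns the aryl group on the saturated ring carbon, and there one aryl group replaced another with the number essentially unchanged. Because that step a 1.1-fold lower number from compound 1 to compound 2 (0.04 log units; within the scatter) lay within the scatter, and because compound 2 sits at 190 nM, the step expected here is no change at the digits printed from compound 2 to compound 3 (within the scatter), none beyond the scatter. Compound 3 is therefore estimated at 190 nM in this assay, with a range from 90 nM to 400 nM.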

Compound 3, concentration for 50% growth inhibition: 200 nM
Compound 3: middle estimate off by 1.1-fold (0.02 log units), on the low side, within the range that was stated.
By their numbers in this assay, from the lowest: compounds 2, 3 and 1 (each within the scatter of the next).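

In this assay, among the compounds shown here, the step from plain phenyl to 4-methoxyphenyl is the first reading at this position: a 1.1-fold higher number from compound 2 to compound 3 (0.02 log units; within the scatter) leaves the two compounds indistinguishable. The earlier step concerned only the aryl group on the saturated ring carbon, whereas this one shows that methoxy can take the place of hydrogen on the aromatic carbon para to a large group without a change beyond the scatter. Nothing given here accounts for this result.

Methoxy is the only group shown at this carbon, so the compounds leave open whether an amine, a carboxylic acid or a longer alkoxy chain in the same place would also stay within the scatter of compound 2. They also leave open whether methoxy on another carbon of this ring would give the same reading, and whether the absence of a clear difference between compound 2 and compound 3 holds for a group larger than methoxy.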